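Replacing thiophen-3-yl with furan-2-yl on a shared core

The source may hold more compounds than are shown below. What is called first, only, known or untested is meant among the compounds shown, and "the series" means these compounds.

Values in a functional assay on HeLa cells (Homo sapiens) for cytotoxicity, read by CCK-8 assay; on this read-out higher numbers stand for weaker inhibition and lower numbers for stronger inhibition:
Compound 1 `Oc1ccc(-c2cc(-c3ccsc3)cc(-c3ccccc3O)n2)cc1`: > 50000 nM (a limit)
Compound 2 `Oc1cccc(-c2cc(-c3ccsc3)cc(-c3cccc(O)c3)n2)c1`: 16600 nM
Compound 3 `Oc1ccc(-c2cc(-c3ccsc3)cc(-c3cccc(O)c3)n2)cc1`: 2580 nM

For the measured compounds named here, compound 3 gives 2580 nM, the lowest number of the three and the strongest inhibition in this assay so far. Compound 1 reaches only a limit of the assay, > 50000 nM, and not a number.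

Two measured steps lead to compound 3. One is an at least 19-fold lower number from compound 1 to compound 3 (1.28 log units; beyond the scatter) for 3-hydroxyphenyl in place of 2-hydroxyphenyl. The other is a 6.4-fold lower number from compound 2 to compound 3 (0.81 log units; beyond the scatter) for 4-hydroxyphenyl in place of 3-hydroxyphenyl.

Compound 4 `Oc1ccc(-c2cc(-c3ccco3)cc(-c3cccc(O)c3)n2)cc1` keeps both hydroxyphenyl groups of compound 3 but carries furan-2-yl in place of thiophen-3-yl on an aromatic carbon on the aromatic carbon opposite the ring nitrogen. Neither measured step changes this group, so they show only how far the numbers can move in this series and give no direction here. Little movement is therefore expected, most likely none beyond the scatter, and the estimate stays anchored on compound 3 at 2580 nM in this assay.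

The expected step is a 1.2-fold higher number from compound 3 to compound 4 (0.07 log units; within the scatter).

For compound 4 the estimated value is 3000 nM, with an expected range from 1000 nM to 9000 nM.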

Compound 4, half-maximal inhibitory concentration: 5170 nM
For compound 4 the middle estimate is 1.7-fold (0.24 log units) below the measured one, within the range that was stated.
By their numbers in this assay, from the lowest: compounds 3 and 4 (each within the scatter of the next); then compound 2. At a limit, above all of these: compound 1.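

The earlier compounds shown here moved only the hydroxyphenyl groups and kept thiophen-3-yl fixed, so compound 4 adds the only view of the position opposite the ring nitrogen. In this assay, furan-2-yl in place of thiophen-3-yl gives a 2.0-fold higher number from compound 3 to compound 4 (0.30 log units; within the scatter), so unlike the two hydroxyphenyl steps, this exchange of one five-membered aromatic ring for another does not move the number beyond the scatter. The data shown offer no explanation for this step.

As far as these compounds go, this single step changes both the hetero atom, from sulfur to oxygen, and the point of attachment, so their separate contributions stay open. Also open, from the compounds shown here alone, is how the number would respond to an amine, a carboxylic acid or a longer chain at this position.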